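Cyclopentylamino replacing cyclohexylsulfanyl on the methylated core

A few compounds are considered here, and "the series" means these few. Any claim that something is new, unique, unknown or untested is made for them only; others in the source may bear on it.

Compound 3 `Cc1cc(SC2CCCCC2)nc(Nc2ccc(C#N)cc2)n1` is read in an ADME assay on MT4 cells (Homo sapiens) for cytotoxicity, read by MTT assay (on this read-out lower numbers stand for higher toxicity in this test and higher numbers for lower toxicity in this test), only as a limit, and in this assay compound 3 gives >= 192000 nM. That places compound 3 at the limit of >= 192000 nM in this assay, at which 1 of the 3 values shown sits; compound 1 `N#Cc1ccc(Nc2nccc(SC3CCCCC3)n2)cc1` is likewise known only through a limit. In this assay compound 1 gives > 402000 nM. For the measured compounds named here, compound 2 `N#Cc1ccc(Nc2nccc(NC3CCCCC3)n2)cc1` supplies the one measured number of the set: in this assay compound 2 gives 7330 nM.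

Compound 4 `Cc1cc(NC2CCCC2)nc(Nc2ccc(C#N)cc2)n1` has not yet been measured. It differs from compound 3 in a single place: cyclopentylamino in place of cyclohexylsulfanyl on an aromatic carbon.

Going by the values given here, two measured steps bear on this change. The exchange of the sulfur-linked ring for a nitrogen-linked ring is seen in an at least 54-fold lower number from compound 1 to compound 2 (1.73 log units; beyond the scatter), a move from the limit at the limit of > 402000 nM in this assay, at which 1 of the 3 values shown sits, to a measured number. The methyl that separates compound 3 from compound 1 gives a step that the two limits leave unreadable from compound 1 to compound 3, so the two limits say nothing about its size. Among the compounds with values here, the ring of compound 4 is cyclopentyl rather than cyclohexyl, and no measured pair covers that difference.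

The step is therefore expected to follow the step from compound 1 to compound 2 in direction and roughly in size, giving an expected at least 16-fold lower number from compound 3 to compound 4 (1.20 log units; beyond the scatter). Compound 4 is estimated in this assay at 12000 nM. The expected range runs from 3000 nM to 60000 nM. A reading that again stops at a limit cannot be excluded.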

Compound 4, half-maximal cytotoxic concentration: 310 nM
Compound 4: the middle estimate sits 39-fold (1.59 log units) above what was measured; the whole stated range lies above it.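

On the methylated core, the change at the aromatic carbon next to the ring nitrogen gives, in this assay, an at least 610-fold lower number from compound 3 to compound 4 (2.79 log units; beyond the scatter), so the direction of an at least 54-fold lower number from compound 1 to compound 2 (1.73 log units; beyond the scatter) now appears on a second core and with a different ring size. Compound 3 is known only as a limit, which makes the new step a lower bound on size and not a measured distance: the limit of >= 192000 nM in this assay, at which 1 of the 4 values shown sits. Across the four compounds, both with a nitrogen-linked ring give measured numbers and both with cyclohexylsulfanyl stop at limits, with none going against this split, while the step that adds the methyl to compound 1 cannot be read.

Going by these compounds, compound 3 and compound 4 differ in both the linking atom and the ring, so the share of the step belonging to each remains open, and cyclopentylsulfanyl or cyclohexylamino on the methylated core would separate the two. Also open, on these data alone, is whether the lower number requires a ring at all or extends to an open-chain amine such as diethylamino, and whether a cyclohexyloxy group at this position stays with the sulfur-linked compounds or with the nitrogen-linked ones.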